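Methyl in place of methoxy on a fused aromatic core

The source may report more compounds than this note shows. Statements on the series, on what has been measured and on what is new or still open speak of the compounds shown alone.

For the measured compounds named here, compound 1 `CCC(=O)Oc1c(OC)c(OC)c(OC(=O)CC)c2cc(Cl)ccc12` gives 4.3 in a physicochemical assay for lipophilicity (on this read-out lower numbers stand for lower lipophilicity and higher numbers for higher lipophilicity), while compound 2 `CCC(=O)Oc1c(OC)c(OC)c(OC(=O)CC)c2cc(OC)ccc12` gives 3.28; the only recorded step, a number 1.02 log units lower from compound 1 to compound 2 (beyond the scatter), shows how strongly this single exchange moves the read-out. Going by the values given here, compound 2 thus stands lowest of the two numbers so far. Compound 3 `CCC(=O)Oc1c(OC)c(OC)c(OC(=O)CC)c2cc(C)ccc12` differs from compound 2 by methyl in place of methoxy on an aromatic carbon. Among the compounds with values here, no measured step addresses this exact swap, but the size of a number 1.02 log units lower from compound 1 to compound 2 (beyond the scatter) suggests a change at that position can exceed the scatter. Compound 3 is therefore expected to rise by a number 0.62 log units higher from compound 2 to compound 3 (beyond the scatter), to an estimated 3.9 with a range of 3.5 to 4.3.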

Compound 3, partition coefficient: 3.9
For compound 3 middle estimate and measured number coincide at the digits printed; the range from low to high includes it.
By their numbers in this assay, from the lowest: compound 2; then compound 3; then compound 1.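

In this assay this aromatic carbon now shows three separate levels: methyl in place of methoxy gives a number 0.62 log units higher from compound 2 to compound 3 (beyond the scatter) and methyl in place of chloro gives a number 0.40 log units lower from compound 1 to compound 3 (beyond the scatter) in the same setting. Methyl therefore matches neither earlier group, and its compound lies between the other two, with both steps beyond the scatter. No evidence is available to explain this order. From the compounds shown here alone, whether an amine, a carboxylic acid or a longer chain at this carbon would fall inside this span remains open.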